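Acetyl in place of aminoethyl carbonyl on a tricyclic core

The source may hold more compounds than are shown below. What is called first, only, known or untested is meant among the compounds shown, and "the series" means these compounds.

Measured compounds:
Compound 1 `Cc1c2c(n3c1CCN(C(=O)[C@H](C)N)CC[C@H](C)Nc1cc-3ccc1C(N)=O)CC(C)(C)CC2=O` — 314 nM
Compound 2 `Cc1c2c(n3c1CCCN(C(=O)[C@@H](C)N)[C@H](C)CNc1cc-3ccc1C(N)=O)CC(C)(C)CC2=O` — > 5000 nM

The study follows the step from compound 1 to compound 3. Among the measured compounds shown here, in a functional assay on HCT-116 cells (Homo sapiens) for antiproliferative activity (a higher number here means that more compound is needed for the effect, a lower number that less compound is needed), compound 1 gives 314 nM, the only number among the two values shown. Compound 2 reaches only the limit of the assay, > 5000 nM, which is a limit and not a number (the limit of > 5000 nM in this assay, at which 1 of the 2 values shown sits). No step between measured compounds differing in one place is shown, so no measured step sets the scale. Compound 3 `CC(=O)N1CCc2c(C)c3c(n2-c2ccc(C(N)=O)c(c2)N[C@@H](C)CC1)CC(C)(C)CC3=O` differs from compound 1 by methyl in place of 1-aminoethyl on a carbonyl carbon. For the measured compounds named here, as the two measured compounds are not a single-point pair, there is no direct precedent for the size of this change. Removal of a group of three heavy atoms with a donor and an acceptor is expected to weaken activity in this assay beyond the scatter. Compound 3 is therefore estimated at 1500 nM (range 300 nM to 5000 nM), an expected step of a 4.8-fold higher number from compound 1 to compound 3 (0.68 log units; beyond the scatter).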

Compound 3, half-maximal effective concentration in the HCT-116 assay: 151 nM
Compound 3: the middle estimate sits 9.9-fold (1.00 log units) above what was measured, and the stated range ends above it.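

In the HCT-116 assay, the 1-aminoethyl on this carbonyl carbon proves unnecessary for the effect, as replacing it with methyl gives a 2.1-fold lower number from compound 1 to compound 3 (0.32 log units; beyond the scatter). The same change does not read the same way in a physicochemical assay for solubility (on this read-out higher numbers stand for higher solubility and lower numbers for lower solubility), where it gives an at least 5.2-fold lower number from compound 1 to compound 3 (0.72 log units; beyond the scatter). In the physicochemical assay compound 3 gives 19 ug/mL. In the physicochemical assay compound 1 gives > 100 ug/mL, which is a limit of the assay and not a number, so the true size of this step stays unknown: the limit of > 100 ug/mL in the physicochemical assay, at which 1 of the 2 values shown sits.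

The compounds shown leave open whether an ethyl group on the same carbonyl carbon would match compound 3 or compound 1 in both assays, which would separate the contribution of the amine from that of the carbon chain. They also leave open whether a hydroxymethyl group or a longer aminoalkyl chain there would keep the lower number in the HCT-116 assay while giving a higher one in the physicochemical assay.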